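This account rests on a few compounds, and the source may have more. Where it says the series, first, only, none or still open, it means among the compounds named here.

Working notes on the series. Compound 1 `O=C(N/N=C/c1ccc2c(c1)no[n+]2[O-])c1ccc(Cl)c(Cl)c1` and compound 2 `Nc1ccc(C(=O)N/N=C/c2ccc3c(c2)no[n+]3[O-])cc1` share the same core and differ in the group on the benzoyl ring. In an ADME assay on cells (Fibroblast, Homo sapiens) for inhibition, read by MTT assay, with a stated time of 24 h (a lower number here means a stronger inhibitor, a higher number a weaker inhibitor), compound 1 gives 65000 nM. Compound 2 reaches only the upper limit of this assay, > 200000 nM, which is a limit and not a number; this is the limit of > 200000 nM in this assay, at which 1 of the 2 values shown sits, so compound 2 stands at the weak end of what the two measured values show, with no firm number to place it against compound 1.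

Compound 3 `CCCCc1ccc(C(=O)N/N=C/c2ccc3c(c2)no[n+]3[O-])cc1` is the next member, not yet measured in this assay. It differs from compound 2 as butyl in place of amino on an aromatic carbon. Compound 1 carries two chlorines in place of the amino and gives a number rather than a limit, so a step toward stronger inhibition, beyond the scatter, is expected from compound 2 to compound 3, an at least 2.8-fold lower number from compound 2 to compound 3 (0.45 log units; beyond the scatter). Compound 3 is expected to give about 70000 nM, within roughly 25000 nM to 200000 nM.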

Compound 3, half-maximal inhibitory concentration: > 200000 nM
Compound 3: no number, only a limit; the forecaster's own chance of this, stated with the estimate: 30%; at least 2.8-fold (0.45 log units) between middle value and limit.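

No step can be read from compound 2 to compound 3 in this assay, since both give a limit and not a number: the limit of > 200000 nM in this assay, at which 2 of the 3 values shown sit.

The compounds shown leave open whether butyl in place of amino on an aromatic carbon changes inhibition at all, and by how much.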